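Enlarging the silyl group in the thiourea series

The compounds below may be only part of what the source reports. "The series", "measured", "known", "first", "only" and "open" are said of these compounds alone.

Compound 1 `C[Si](C)(C)c1ccc(CNC(=S)NCc2ccc(NS(C)(=O)=O)cc2)cc1` gives 150 nM in a functional assay on cells (strain Sprague-Dawley) for antagonist activity at transient receptor potential cation channel subfamily V member 1 (Rattus norvegicus), read by scintillation counting; on this read-out higher numbers stand for weaker inhibition and lower numbers for stronger inhibition.
Compound 2 `CC[Si](CC)(CC)c1ccc(CNC(=S)NCc2ccc(NS(C)(=O)=O)cc2)cc1` gives 3100 nM in this assay.
Compound 3 `C[C@@H](NC(=S)NCc1ccc([Si](C)(C)C)cc1)c1ccc(NS(C)(=O)=O)cc1` gives 210 nM in this assay.

Compound 3 stands second highest of the three numbers in this assay. Its nearest neighbour is compound 1, separated by a 1.4-fold higher number from compound 1 to compound 3 (0.15 log units; within the scatter), which is within the scatter; its furthest is compound 2, whose number is much higher than that of compound 3.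

Compound 4 `CC[Si](CC)(CC)c1ccc(CNC(=S)N[C@H](C)c2ccc(NS(C)(=O)=O)cc2)cc1` differs from compound 3 by a group of 7 heavy atoms (6 carbon, 1 silicon; no ring) in place of a group of 4 heavy atoms (3 carbon, 1 silicon; no ring), on an aromatic carbon. The same change has been measured once in this series, as a 21-fold higher number from compound 1 to compound 2 (1.32 log units; beyond the scatter), a large step beyond the scatter. Within the data shown here, that is the only measured step bearing directly on the question; the methyl on the chain carbon, which compound 3 and compound 4 share, moved the number only by a 1.4-fold higher number from compound 1 to compound 3 (0.15 log units; within the scatter), so it is not expected to change the picture. A step of similar size, upward towards weaker inhibition, is therefore expected in this assay: a 21-fold higher number from compound 3 to compound 4 (1.32 log units; beyond the scatter). Compound 4 is estimated to give 4400 nM, within a range from 1500 nM to 13000 nM.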

Compound 4, half-maximal inhibitory concentration: 1500 nM
Estimate against measurement, compound 4: 2.9-fold (0.47 log units) above; the measured number falls inside the stated range.
By their numbers in this assay, from the lowest: compounds 1 and 3 (each within the scatter of the next); then compound 4; then compound 2.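

On the core carrying the chain methyl, the group of 7 heavy atoms still weakens inhibition in this assay, with a 7.1-fold higher number from compound 3 to compound 4 (0.85 log units; beyond the scatter), but the size of this step depends on the core: the same change on two cores in this assay, a 21-fold higher number (1.32 log units; beyond the scatter) from compound 1 to compound 2 and a 7.1-fold higher number (0.85 log units; beyond the scatter) from compound 3 to compound 4, 2.9-fold (0.46 log units) apart, beyond the scatter of two such steps. Read the other way, the chain methyl is not neutral throughout, since with the larger silyl group in place it gives a 2.1-fold lower number from compound 2 to compound 4 (0.32 log units; beyond the scatter), in the direction of stronger inhibition, and its effect also differs between the two cores: the same change on two cores in this assay, a 1.4-fold higher number (0.15 log units; within the scatter) from compound 1 to compound 3 and a 2.1-fold lower number (0.32 log units; beyond the scatter) from compound 2 to compound 4, 2.9-fold (0.46 log units) apart, beyond the scatter of two such steps. The two silyl changes and the two methyl changes therefore do not add independently, although this rests on a single set of four compounds.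

Going by these compounds, whether this dependence extends to other groups on the aromatic carbon, such as a tert-butyl group or a longer chain, remains open. On these data alone, the effect of the opposite configuration at the chain carbon also remains open.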